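The source may hold more compounds than are shown below. What is called first, only, known or untested is meant among the compounds shown, and "the series" means these compounds.

Compound 1 `CC(=O)Nc1ccc(-n2nncc2CN2C(=O)C3(C(C#N)=C(N)Oc4c3c3nc5ccccc5nc3c3ccccc43)c3ccccc32)cc1` and compound 2 `Cc1ccc(-n2nncc2CN2C(=O)C3(C(C#N)=C(N)Oc4c3c3nc5ccccc5nc3c3ccccc43)c3ccccc32)c(C)c1` share a core with the compounds that follow and differ only in the group on an aromatic nitrogen. In a functional assay on A549 cells (Homo sapiens) for antiproliferative activity, read by MTT assay, with a stated time of 48 h (on this read-out higher numbers stand for weaker inhibition and lower numbers for stronger inhibition), compound 1 gives > 50000 nM, which is a limit of the assay and not a number. Compound 2 gives > 50000 nM, again a limit. The resulting step, 2,4-dimethylphenyl in place of 4-acetamidophenyl, is a step that the two limits leave unreadable from compound 1 to compound 2, because both ends rest at the limit of > 50000 nM in this assay, at which 2 of the 3 values shown sit.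

Among the measured compounds shown here, compound 3 `N#CC1=C(N)Oc2c(N)cc3nc4ccccc4nc3c2C12C(=O)N(Cc1cnnn1-c1cccc(Br)c1)c1ccccc12` is the one compound with a measured number: in this assay compound 3 gives 18900 nM.

Compound 4 `N#CC1=C(N)Oc2c(N)cc3nc4ccccc4nc3c2C12C(=O)N(Cc1cnnn1-c1ccc([N+](=O)[O-])cc1[N+](=O)[O-])c1ccccc12` differs from compound 3 in one place: 2,4-dinitrophenyl in place of 3-bromophenyl on an aromatic nitrogen. For the measured compounds named here, no measured step concerns this exchange, and the one step that exists between measured compounds cannot be read in size. The expected step of a 1.2-fold higher number from compound 3 to compound 4 (0.07 log units; within the scatter) is therefore none beyond the usual scatter. Compound 4 is estimated at 22000 nM, with a range from 6000 nM to 80000 nM.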

Compound 4, half-maximal inhibitory concentration: > 50000 nM
Compound 4: only a limit was reported; the forecaster's own chance of this, stated with the estimate: 30%; middle value at least 2.2-fold (0.35 log units) away from the limit.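

Among the compounds shown here, this is the first exchange of the group on the aromatic nitrogen whose size can be read: in this assay, 2,4-dinitrophenyl in place of 3-bromophenyl gives an at least 2.6-fold higher number from compound 3 to compound 4 (0.42 log units; beyond the scatter) and so means weaker inhibition. The group at this position therefore changes the read-out on the core of compound 3, something the unreadable step between compound 1 and compound 2 could not show. Only the minimum size of this step is known, since the result for compound 4 is a limit of the assay and not a number: the limit of > 50000 nM in this assay, at which 3 of the 4 values shown sit.

The compounds shown leave open whether the loss follows from removing the bromine or from adding the two nitro groups. A plain phenyl or a 4-nitrophenyl group on the same core could help separate these two parts of the exchange.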